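Cyclobutyl in place of methyl: an expected gain in potency

The compounds below may be only part of what the source reports. "The series", "measured", "known", "first", "only" and "open" are said of these compounds alone.

Three compounds share the amide-linked acid and the five-membered aromatic ring with 3 nitrogen. Compound 1 `C[C@H](NC(=O)c1nnn(CCOc2ccc(F)cc2)c1C(F)(F)F)c1ccc(C(=O)O)cc1` reaches only a limit in a functional assay on CHO cells for antagonist activity at prostaglandin E2 receptor EP4 subtype (Homo sapiens), read by calcium flux, with a stated time of 15 min (a higher number here means a weaker inhibitor, a lower number a stronger inhibitor), namely > 10000 nM. Compound 2 `Cc1nnn(Cc2ccc(C(F)(F)F)cc2)c1C(=O)N[C@@H](C)c1ccc(C(=O)O)cc1` likewise gives only a limit in this assay, > 10000 nM. For the measured compounds named here, compound 3 `COc1cccc(Cn2nnc(-c3ccccc3)c2C(=O)N[C@@H](C)c2ccc(C(=O)O)cc2)c1`, which carries a phenyl on the ring carbon, is the one compound with a number, 96.8 nM. Going by the values given here, compound 2 thus stands at the limit of > 10000 nM in this assay, at which 2 of the 3 values shown sit, and no comparison between measured compounds turns on a single change.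

Compound 4 `C[C@H](NC(=O)c1c(C2CCC2)nnn1Cc1ccc(C(F)(F)F)cc1)c1ccc(C(=O)O)cc1` differs from compound 2 by cyclobutyl in place of methyl on an aromatic carbon. Compound 4 is expected to gain in this assay, with an estimate of 2000 nM between 300 nM and 10000 nM. The expected step of an at least 5.0-fold lower number from compound 2 to compound 4 (0.69 log units; beyond the scatter) is taken beyond the scatter, since compound 3 with a larger group on that carbon gives 96.8 nM, though compound 3 also differs at the benzyl position and so the expectation is uncertain.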

Compound 4, half-maximal inhibitory concentration: 75.3 nM
Compound 4: middle estimate off by 27-fold (1.42 log units), on the high side; measured number below the stated range.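

In this assay, cyclobutyl in place of methyl on this aromatic carbon gives an at least 130-fold lower number from compound 2 to compound 4 (2.12 log units; beyond the scatter), with the rest of the compound unchanged. For the compounds shown here, this is the first comparison here that turns on a single change, and it ties the gain to this one position, where the entering group is a four-membered non-aromatic ring of carbon only. On these data alone, the true size of the step stays unknown, since compound 2 gives only a limit: the limit of > 10000 nM in this assay, at which 2 of the 4 values shown sit.

The compounds shown leave open whether the ring itself or simply the larger number of carbons goes with the gain, a question on which an open-chain tert-butyl or a smaller cyclopropyl at this carbon would bear. They also leave open how an ether or an amine on the same carbon would read in this assay.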